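Methoxy in Place of Chloro on the Benzamide of Compound 1

The source may report more compounds than this note shows. Statements on the series, on what has been measured and on what is new or still open speak of the compounds shown alone.

Going by the values given here, compound 1 `O=C(Nc1cccc(/C=C/C(=O)c2nc3ccccc3[nH]2)c1)c1ccc(Cl)cc1` gives 2270 nM in a functional assay on HCT-116 cells (Homo sapiens) for antiproliferative activity, read by MTT assay, with a stated time of 48 h (on this read-out higher numbers stand for weaker inhibition and lower numbers for stronger inhibition), the highest of the three numbers measured so far, though every step from it stays within the scatter. Compound 2 `O=C(Nc1cccc(/C=C/C(=O)c2nc3ccccc3[nH]2)c1)c1ccc(Br)cc1` gives 2230 nM and compound 3 `Cc1ccc(C(=O)Nc2cccc(/C=C/C(=O)c3nc4ccccc4[nH]3)c2)cc1` gives 1660 nM. Compound 4 `COc1ccc(C(=O)Nc2cccc(/C=C/C(=O)c3nc4ccccc4[nH]3)c2)cc1` differs from compound 1 by methoxy in place of chloro on an aromatic carbon. Among the compounds with values here, the steps that bear on this are the other exchanges on an aromatic carbon: a 1.0-fold lower number from compound 1 to compound 2 (0.01 log units; within the scatter), a 1.4-fold lower number from compound 1 to compound 3 (0.14 log units; within the scatter) and a 1.3-fold lower number from compound 2 to compound 3 (0.13 log units; within the scatter), all within the scatter. Within the data shown here, no measured compound carries methoxy, so the expectation rests on these small steps alone. Compound 4 is therefore expected to differ from compound 1 by no more than the scatter, a 1.2-fold lower number from compound 1 to compound 4 (0.08 log units; within the scatter). Compound 4 is estimated at 1900 nM, with a range from 900 nM to 4000 nM.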

Compound 4, half-maximal inhibitory concentration: 4880 nM
Estimate against measurement, compound 4: 2.6-fold (0.41 log units) below; the whole stated range lies below it.
By their numbers in this assay, from the lowest: compounds 3, 2 and 1 (each within the scatter of the next); then compound 4.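

In this assay, going by these compounds alone, the position para to a large group had so far tolerated exchange without a change beyond the scatter, but methoxy gives the first steps beyond it (a 2.1-fold higher number from compound 1 to compound 4 (0.33 log units; beyond the scatter)) and (a 2.2-fold higher number from compound 2 to compound 4 (0.34 log units; beyond the scatter)) and (a 2.9-fold higher number from compound 3 to compound 4 (0.47 log units; beyond the scatter)). Methoxy therefore stands apart from chloro, bromo and methyl here, and the position is not indifferent to every group placed on it. Nothing available explains why this exchange weakens inhibition. As far as these compounds go, whether ethoxy, hydroxy or an amine at this position would follow methoxy or the other three groups remains open. So does whether methoxy would give a similar step elsewhere on this ring.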